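Swapping the halogenated phenyl on the pyrazole-like core nitrogen

The compounds below may be only part of what the source reports. "The series", "measured", "known", "first", "only" and "open" are said of these compounds alone.

Measured compounds in an ADME assay on Huh-7 cells (Homo sapiens) for cytotoxicity; on this read-out higher numbers stand for lower toxicity in this test and lower numbers for higher toxicity in this test:
- compound 1 `Cc1ccccc1-c1nn(-c2ccc(Cl)cc2)cc1CNCCN1CCN(C)CC1`: 17000 nM
- compound 2 `Cc1ccccc1-c1nn(-c2ccccc2Cl)cc1CNCCN1CCN(C)CC1`: a limit, > 20000 nM
- compound 3 `Cc1ccccc1-c1nn(-c2ccc(F)c(F)c2)cc1CNCCN1CCN(C)CC1`: a limit, > 20000 nM

Compound 3 sits at the limit of this assay; its value is not a number, and (the limit of > 20000 nM in this assay, at which 2 of the 3 values shown sit). Compound 4 `Cc1ccccc1-c1nn(-c2ccc(Br)cc2)cc1CNCCN1CCN(C)CC1` differs from compound 3 by 4-bromophenyl in place of 3,4-difluorophenyl on an aromatic nitrogen. Among the measured compounds shown here, two measured steps bear on this: an at least 1.1-fold higher number from compound 1 to compound 3 (0.07 log units; that floor lies within the scatter) and a step that the two limits leave unreadable from compound 2 to compound 3. Compound 1 carries a 4-chlorophenyl, the closest measured relative of the 4-bromophenyl, and its number lies near the limit. Compound 4 is therefore expected to show no step beyond the scatter, a number no higher from compound 3 to compound 4 (the limit leaves the size open). The estimate for compound 4 is 20000 nM, ranging from 10000 nM to 40000 nM.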

Compound 4, half-maximal cytotoxic concentration: 9600 nM
Beside the measured number, compound 4's estimate is 2.1-fold (0.32 log units) above it; the whole stated range lies above it.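

On this read-out, the group on the aromatic nitrogen now gives steps beyond the scatter: 4-bromophenyl in place of 3,4-difluorophenyl gives an at least 2.0-fold lower number from compound 3 to compound 4 (0.31 log units; beyond the scatter), and in place of 2-chlorophenyl it gives an at least 2.0-fold lower number from compound 2 to compound 4 (0.31 log units; beyond the scatter). Bromo in place of chloro gives a 1.8-fold lower number from compound 1 to compound 4 (0.25 log units; within the scatter), so this halogen swap cannot be told apart from repeat-measurement noise. The first two steps give only a minimum size because their starting compounds sit at a limit: the limit of > 20000 nM in this assay, at which 2 of the 4 values shown sit.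

Still open, on these data alone, is how an unsubstituted phenyl or a 4-methoxyphenyl on this nitrogen would read. As far as these compounds go, the true values of compound 2 and compound 3 also remain unknown.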